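The source may hold more compounds than are shown below. What is called first, only, known or untested is meant among the compounds shown, and "the series" means these compounds.

Compound 1 `COc1ccc(/C=C/C(=O)c2ccc(OC)c3c2OC(C)(C)C=C3)cc1O` gives in a functional assay on A-375 cells (Homo sapiens) for cytotoxicity, read by MTT assay (a higher number here means a weaker inhibitor, a lower number a stronger inhibitor), a value of 800 nM.
Compound 2 `COc1ccc(/C=C/C(=O)c2ccc(OC)c3c2OC(C)(C)C=C3)cc1OCCCN(C)C` gives in this assay a value of 4100 nM.
Compound 3 `COc1ccc(/C=C/C(=O)c2ccc(OC)c3c2OC(C)(C)C=C3)cc1OC(=O)C1CC1` gives in this assay a value of 380 nM.

Compound 3 stands lowest of the three: a 2.1-fold lower number from compound 1 to compound 3 (0.32 log units; beyond the scatter), and an 11-fold lower number from compound 2 to compound 3 (1.03 log units; beyond the scatter). Compound 4 `COc1ccc(/C=C/C(=O)Oc2cc(/C=C/C(=O)c3ccc(OC)c4c3OC(C)(C)C=C4)ccc2OC)cc1` differs from compound 3 in one place: 2-(4-methoxyphenyl)ethenyl in place of cyclopropyl on a carbonyl carbon. Both groups sit on a carbonyl carbon whose other neighbour is oxygen next to a carbonyl group. Among the measured compounds shown here, no measured step exchanges one acyl group for another. The steps that touch this oxygen are a 2.1-fold lower number from compound 1 to compound 3 (0.32 log units; beyond the scatter), a modest gain, and a 5.1-fold higher number from compound 1 to compound 2 (0.71 log units; beyond the scatter), a larger move upward; neither is a close precedent for compound 4. The expectation for compound 4 in this assay is therefore a number close to that of compound 3, with a 1.3-fold higher number from compound 3 to compound 4 (0.12 log units; within the scatter) expected, not beyond the scatter. Compound 4 is estimated at 500 nM, in the range 200 nM to 1500 nM.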

Compound 4, half-maximal inhibitory concentration: 2630 nM
For compound 4 the middle estimate is 5.3-fold (0.72 log units) below the measured one; measured number outside the range, above it.
By their numbers in this assay, from the lowest: compound 3; then compound 1; then compounds 4 and 2 (each within the scatter of the next).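

On this oxygen the identity of the acyl group matters: in this assay, 2-(4-methoxyphenyl)ethenyl in place of cyclopropyl on the carbonyl carbon gives a 6.9-fold higher number from compound 3 to compound 4 (0.84 log units; beyond the scatter), so acylation as such does not carry the gain seen with compound 3. The larger acyl group also gives a 3.3-fold higher number from compound 1 to compound 4 (0.52 log units; beyond the scatter), the opposite direction to cyclopropylcarbonyl, while a 1.6-fold lower number from compound 2 to compound 4 (0.19 log units; within the scatter) leaves it level with the 3-(dimethylamino)propyl ether. Nothing available here explains these shifts. As far as these compounds go, whether an acetyl group, or an acyl group carrying an amine, would fall nearer compound 3 or compound 4 stays open. So does whether the ethenyl link or the 4-methoxyphenyl ring accounts for the step.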